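This account rests on a few compounds, and the source may have more. Where it says the series, first, only, none or still open, it means among the compounds named here.

Two hydrazones sharing the same dibenzyl hydrazine core have been measured in an assay on liver (Sus scrofa) for inhibition of glucose-6-phosphatase catalytic subunit 1 (Homo sapiens), using microsomes; a higher number here means a weaker inhibitor, a lower number a stronger inhibitor. Compound 1, `C(=N/N(Cc1ccccc1)Cc1ccccc1)\c1ccccc1`, gives 1500 nM. Compound 2, `C(=N/N(Cc1ccccc1)Cc1ccccc1)\c1cccnc1`, gives 3700 nM, which is the higher of the two numbers, so compound 2 stands as the weaker of the pair. Among the compounds with values here, the only measured step is a 2.5-fold higher number from compound 1 to compound 2 (0.39 log units; beyond the scatter).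

Compound 3, `OCc1ccc(/C=N/N(Cc2ccccc2)Cc2ccccc2)o1`, has not yet been measured. It differs from compound 2 in one place: 5-(hydroxymethyl)furan-2-yl in place of pyridin-3-yl on a carbon with a double bond to nitrogen. Within the data shown here, no measured step tells what a furan in this position, or a hydroxymethyl on it, does in this assay; the single measured step concerns a different exchange of the aromatic group on the same carbon, and it was modest. With nothing bearing directly on the new change, the expectation for compound 3 is that it stays near compound 2, with a wide band to either side. The estimated step of a 1.2-fold lower number from compound 2 to compound 3 (0.09 log units; within the scatter) is therefore small. Compound 3 is thus estimated at 3000 nM, within a range from 800 nM to 12000 nM.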

Compound 3, half-maximal inhibitory concentration: 16000 nM
Compound 3: middle estimate off by 5.3-fold (0.73 log units), on the low side, outside the stated range (above it).
By their numbers in this assay, from the lowest: compound 1; then compound 2; then compound 3.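

In this assay, within the data shown here, the carbon with a double bond to nitrogen turns out to tolerate exchange of its aromatic group less well than the first pair suggested: 5-(hydroxymethyl)furan-2-yl in place of pyridin-3-yl gives a 4.3-fold higher number from compound 2 to compound 3 (0.64 log units; beyond the scatter) and, in place of phenyl, gives an 11-fold higher number from compound 1 to compound 3 (1.03 log units; beyond the scatter), the one large step in this small set. Both aromatic groups tried in place of phenyl raise the number, and the order now runs from phenyl through pyridin-3-yl to 5-(hydroxymethyl)furan-2-yl, which leaves compound 1 the strongest inhibitor of the three. No supporting measurement is available to explain why this exchange weakens inhibition.

The exchange changes the ring and adds a hydroxymethyl at once, so the compounds shown cannot divide the loss between the furan and its substituent, and an unsubstituted furan-2-yl, or a carboxylic acid or aminomethyl in place of the hydroxymethyl, would be needed to tell these apart. On these data alone, all three compounds also keep the same pair of benzyl groups on the hydrazine nitrogen, so how the number responds to any change there remains open.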